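Stripping the methoxy group from compound 1

The source may report more compounds than this note shows. Statements on the series, on what has been measured and on what is new or still open speak of the compounds shown alone.

Compound 1 `COc1ccc(-c2nc3sc(-c4ccccc4)cn3n2)cc1` — 32%
Compound 2 `COc1cc(-c2nc3sc(-c4ccccc4)cn3n2)cc(OC)c1OC` — 15%
Compound 3 `COc1ccc(-c2nc3sc(-c4ccc(Cl)cc4)cn3n2)cc1` — -74%

Of the compounds shown here, three sharing one core have been measured in a functional assay on ACHN cells (Homo sapiens) for inhibition, read by sulforhodamine B assay, with a stated time of 48 h, tested at 10 uM; on this read-out lower numbers stand for less inhibition of growth and higher numbers for more inhibition of growth at the one concentration tested. Compound 1 stands highest of the three numbers; compound 2 is nearest to it, and compound 3 is furthest, reached through a number 106 percentage points lower from compound 1 to compound 3 (beyond the scatter). Compound 4 `c1ccc(-c2nc3sc(-c4ccccc4)cn3n2)cc1` differs from compound 1 by hydrogen in place of methoxy on an aromatic carbon.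

Going by the values given here, no measured step removes or adds a methoxy group alone. Compound 2 carries two more methoxy groups than compound 1 and its value lies below that of compound 1, which hints that methoxy groups on this ring matter only modestly here. Among the compounds with values here, the single measured step, a number 106 percentage points lower from compound 1 to compound 3 (beyond the scatter), concerns a chloro and was large, so it does not bear directly on the present change. A modest shift is therefore expected, likely downward and perhaps not beyond the scatter, as a number 12 percentage points lower from compound 1 to compound 4 (beyond the scatter). Compound 4 is estimated to give 20%, with a range from -30% to 50%.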

Compound 4, percent growth inhibition at one concentration: 14%
Beside the measured number, compound 4's estimate is 6 percentage points above it, and the stated range covers the measured number.
By their numbers in this assay, from the lowest: compound 3; then compounds 4 and 2 (each within the scatter of the next); then compound 1.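

In this assay, going by these compounds alone, the change from methoxy to hydrogen gives the first direct reading at this position on an aromatic carbon: a number 18 percentage points lower from compound 1 to compound 4 (beyond the scatter) shows that the methoxy group of compound 1 contributes a modest but real part of its growth inhibition. This loss is much smaller than a number 106 percentage points lower from compound 1 to compound 3 (beyond the scatter), which arises from a change elsewhere on the molecule, so removing this group leaves the number positive. Nothing measured here explains why the number falls when methoxy is removed.

From the compounds shown here alone, it remains open whether an amine, a hydroxyl group or a carboxylic acid at this position would match or exceed methoxy. Going by these compounds, it is also open whether a longer ether chain such as ethoxy would behave like methoxy, and whether the methoxy step would keep its size alongside chloro.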